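The source may hold more compounds than are shown below. What is called first, only, known or untested is meant among the compounds shown, and "the series" means these compounds.

Measured compounds:
Compound 1 `CCCCNC(=O)Nc1cc2nc(C3CCCCC3)[nH]c2cc1N(CC)CC` — in an ADME assay on Vero cells (Chlorocebus sabaeus) for cytotoxicity, read by resazurin assay, with a stated time of 3 days (a higher number here means a weaker inhibitor, a lower number a stronger inhibitor), compound 1 gives > 100 ug/mL, which is a limit of the assay and not a number.
Compound 2 `CCCN(CCC)c1cc2[nH]c(C3CCCCC3)nc2cc1NC(=O)c1ccccc1` — in this assay compound 2 gives > 100 ug/mL, likewise a limit.
Compound 3 `Cc1ccc(C(=O)Nc2cc3nc(C4CCCCC4)[nH]c3cc2N2CCCC2)cc1` — in this assay compound 3 gives > 100 ug/mL, also a limit.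

Compound 1 thus stands at the limit of > 100 ug/mL in this assay, at which 3 of the 3 values shown sit. Going by the values given here, none of the three measured compounds shows a number, so no measured step is available from which to read a trend. The unmeasured compound 4 `CCc1ccc(C(=O)Nc2cc3nc(C4CCCCC4)[nH]c3cc2N(CC)CC)cc1` differs from compound 1 in one place: 4-ethylphenyl in place of butylamino on a carbonyl carbon. With all three measured compounds at the limit, no step beyond the scatter is expected in this assay in either direction, and compound 4 is expected to sit at the limit as well. Compound 4 is estimated at 100 ug/mL (range 40 ug/mL to 250 ug/mL), which means an expected step of a number no higher from compound 1 to compound 4 (the limit leaves the size open).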

Compound 4, half-maximal inhibitory concentration: > 100 ug/mL
Compound 4 was reported as a limit; the forecaster's own chance of this, stated with the estimate: 75%; the middle value lies on the limit itself.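

Compound 1 and compound 4 both stand at a limit and not at a number in this assay, so no step between them can be read: the limit of > 100 ug/mL in this assay, at which 4 of the 4 values shown sit.

The compounds shown leave open which change to the shared core, if any, would give a readable number in this assay.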